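Bromo to methyl: notes on compound 3

A few compounds are considered here, and "the series" means these few. Any claim that something is new, unique, unknown or untested is made for them only; others in the source may bear on it.

- Compound 1 `CNC(=O)c1cc(Oc2ccc(NC(=O)c3cc(-c4ccc(C)cc4)ncn3)cc2)ccn1`: 34600 nM
- Compound 2 `CNC(=O)c1cc(Oc2ccc(NC(=O)c3cc(-c4ccc(Br)cc4)ncn3)cc2F)ccn1`: > 100000 nM (a limit of the assay)

Compound 2 gives only a limit in a functional assay on MCF7 cells (Homo sapiens) for cytotoxicity, read by MTT assay, with a stated time of 72 h (a lower number here means a stronger inhibitor, a higher number a weaker inhibitor), > 100000 nM, and not a number. Compound 3 `CNC(=O)c1cc(Oc2ccc(NC(=O)c3cc(-c4ccc(C)cc4)ncn3)cc2F)ccn1` has methyl in place of bromo on an aromatic carbon, para to a large group: methyl in place of bromo on an aromatic carbon. For the measured compounds named here, the series offers no measured step by which to size this change. Going by the values given here, the only number is compound 1 at 34600 nM, and the expectation leans on that value. In this assay a move toward a lower number is expected, of a size the data cannot fix, and compound 3 may yet report only a limit. The expected change is an at least 2.2-fold lower number from compound 2 to compound 3 (0.34 log units; beyond the scatter). The estimate for compound 3 is 45000 nM, with an expected range of 15000 nM to 100000 nM.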

Compound 3, half-maximal inhibitory concentration: 19200 nM
Beside the measured number, compound 3's estimate is 2.3-fold (0.37 log units) above it, and the stated range covers the measured number.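

In this assay, for the compounds shown here, methyl in place of bromo on an aromatic carbon, para to a large group, gives the first step that can be sized at this position: an at least 5.2-fold lower number from compound 2 to compound 3 (0.71 log units; beyond the scatter). That step has no fixed size, since one of its ends is a limit of the assay and not a number: the limit of > 100000 nM in this assay, at which 1 of the 3 values shown sits. Fluoro in place of hydrogen on an aromatic carbon gives a 1.8-fold lower number from compound 1 to compound 3 (0.26 log units; within the scatter), so with methyl present this change cannot be told from the scatter.

The compounds shown leave open how a chloro, an amine or a carboxylic acid would read in place of the methyl. Also open, going by these compounds, is whether the change from 4-bromophenyl to 4-methylphenyl gives a similar step on the core of compound 1, which carries no fluoro.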